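The source may report more compounds than this note shows. Statements on the series, on what has been measured and on what is new or still open speak of the compounds shown alone.

Measured compounds:
- compound 1 `CCCN(CCC)c1cc(C(F)(F)F)ccc1CNC(=O)C(C)c1ccc(NS(C)(=O)=O)c(F)c1` in an assay on CHO cells for antagonist activity at transient receptor potential cation channel subfamily V member 1 (Homo sapiens), read by FLIPR; a lower number here means a stronger inhibitor, a higher number a weaker inhibitor: 0.3 nM
- compound 2 `CC(C(=O)NCc1ccc(C(F)(F)F)cc1OC1CCCC1)c1ccc(NS(C)(=O)=O)c(F)c1` in this assay: 0.6 nM
- compound 3 `CC(C(=O)NCc1ccc(C(F)(F)F)cc1SC1CCCCC1)c1ccc(NS(C)(=O)=O)c(F)c1` in this assay: 0.5 nM

All three compounds share the same core and differ only in the group attached to one aromatic carbon. Compound 3 sits close to both of the others: a 1.2-fold lower number from compound 2 to compound 3 (0.08 log units; within the scatter) and a 1.7-fold higher number from compound 1 to compound 3 (0.22 log units; within the scatter), so the three numbers cannot be told apart with confidence.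

Compound 4 `COc1ccc(CSc2cc(C(F)(F)F)ccc2CNC(=O)C(C)c2ccc(NS(C)(=O)=O)c(F)c2)cc1` takes compound 3 one step further: 4-methoxybenzyl in place of cyclohexyl on a sulfur. The steps already seen, a 2.0-fold higher number from compound 1 to compound 2 (0.30 log units; within the scatter), a 1.7-fold higher number from compound 1 to compound 3 (0.22 log units; within the scatter) and a 1.2-fold lower number from compound 2 to compound 3 (0.08 log units; within the scatter), all swap the whole substituent on that aromatic carbon and all stay within the scatter. None of them replaces only the group on the sulfur, so the new change is not directly covered, but the neighbouring changes suggest this position tolerates variety. A step in this assay of no more than scatter size is therefore expected for compound 4, with no clear direction.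

For compound 4 the expected result in this assay is 0.8 nM, in the range 0.3 nM to 2.5 nM, which corresponds to an expected step of a 1.6-fold higher number from compound 3 to compound 4 (0.20 log units; within the scatter).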

Compound 4, inhibition constant: 2.3 nM
Compound 4: middle estimate off by 2.9-fold (0.46 log units), on the low side; measured number inside the range.
By their numbers in this assay, from the lowest: compounds 1, 3 and 2 (each within the scatter of the next); then compound 4.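

Among the changes on this aromatic carbon, this is the first to go beyond the scatter in this assay: 4-methoxybenzyl in place of cyclohexyl on the sulfur gives (a 4.6-fold higher number from compound 3 to compound 4 (0.66 log units; beyond the scatter)). Compound 4 also stands apart from the two other compounds (a 3.8-fold higher number from compound 2 to compound 4 (0.58 log units; beyond the scatter); a 7.7-fold higher number from compound 1 to compound 4 (0.88 log units; beyond the scatter)), so the tolerance suggested by dipropylamino, cyclopentyloxy and cyclohexylsulfanyl does not extend to every group, although these steps remain modest. No measurement here explains the rise in the number.

A single compound cannot show whether the aromatic ring, the methoxy or the added carbon linking the ring to the sulfur goes with this step; a plain benzyl or phenyl group on the sulfur would help separate these. It also leaves open whether the sulfur matters, which a 4-methoxybenzyloxy group on the aromatic carbon would test.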